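Aryl variation on the triazole-bearing lactam series

This account rests on a few compounds, and the source may have more. Where it says the series, first, only, none or still open, it means among the compounds named here.

Compound 1 `COc1ccccc1-n1cc(CN2C(=O)C[C@@H]3CC[C@@]2(C)C3(C)C)nn1` gives 140 nM in a functional assay on OVCAR-3 cells (Homo sapiens) for inhibition, read by MTT assay, with a stated time of 24 h; on this read-out lower numbers stand for stronger inhibition and higher numbers for weaker inhibition. Compound 2 `CC1(C)[C@H]2CC[C@]1(C)N(Cc1cn(-c3ccccc3C#N)nn1)C(=O)C2` gives 110 nM and compound 3 `CC1(C)[C@H]2CC[C@]1(C)N(Cc1cn(-c3ccc(F)cc3)nn1)C(=O)C2` gives 200 nM. Compound 1 stands among these three numbers with compound 2 nearest, a 1.3-fold lower number from compound 1 to compound 2 (0.10 log units; within the scatter), and compound 3 furthest, a 1.4-fold higher number from compound 1 to compound 3 (0.15 log units; within the scatter); the remaining pair shows a 1.8-fold higher number from compound 2 to compound 3 (0.26 log units; within the scatter). All three lie within the scatter of one another, so no ordering can be read from them.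

Compound 4 `CC1(C)[C@H]2CC[C@]1(C)N(Cc1cn(-c3cccc(O)c3)nn1)C(=O)C2` is not yet measured. Relative to compound 1 the change is 3-hydroxyphenyl in place of 2-methoxyphenyl on an aromatic nitrogen. Every measured step concerns the aryl group on the same aromatic nitrogen, so all three bear on this change, and none exceeded the scatter: the substituent exchange in the step from compound 1 to compound 2 and the whole-ring exchanges in the steps to compound 3 each left the number essentially where it was. For the measured compounds named here, no measured compound carries a 3-hydroxyphenyl, so the effect of a hydrogen-bond donor here is untested.

On this basis compound 4 is expected to show no step beyond the scatter, a 1.1-fold higher number from compound 1 to compound 4 (0.03 log units; within the scatter). The estimate for compound 4 is 150 nM, with a range from 70 nM to 330 nM.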

Compound 4, half-maximal inhibitory concentration: 370 nM
The estimate for compound 4 lay 2.5-fold (0.39 log units) below the measured number; the whole stated range lies below it.
By their numbers in this assay, from the lowest: compounds 2, 1, 3 and 4 (each within the scatter of the next, the first and the last beyond it).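

In this assay, for the compounds shown here, the aryl group on this aromatic nitrogen can move the number: a 2.6-fold higher number from compound 1 to compound 4 (0.42 log units; beyond the scatter) and a 3.4-fold higher number from compound 2 to compound 4 (0.53 log units; beyond the scatter) are the first steps in the set to pass the scatter, both modest in size. The separation is only partial, as a 1.9-fold higher number from compound 3 to compound 4 (0.27 log units; within the scatter) leaves the 3-hydroxyphenyl and 4-fluorophenyl groups indistinguishable, so the result does not set compound 4 apart from all the other compounds. No measurement available here accounts for the step, and the exchange of 2-methoxyphenyl for 3-hydroxyphenyl alters the substituent, its place on the phenyl ring and the count of hydrogen-bond donors all at once.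

Still open, going by these compounds, is which of these alterations matters, a question that 2-hydroxyphenyl and 3-methoxyphenyl groups on the same nitrogen could separate when each is compared with compound 1 or compound 4. Also open, on these data alone, is whether a 3-aminophenyl or 3-carboxyphenyl group would track compound 4 or return to the numbers of compound 1 and compound 2.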